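The source may hold more compounds than are shown below. What is called first, only, known or untested is meant among the compounds shown, and "the series" means these compounds.

Measured so far in an assay on isolated protein for inhibition of serine/threonine-protein kinase TNNI3K (Homo sapiens); a higher number here means a weaker inhibitor, a lower number a stronger inhibitor:
compound 1 `CNc1cc(Oc2ccc(NC(=O)Nc3cccc(C(F)(F)F)c3)cc2)ncn1` gives 40 nM;
compound 2 `COc1cc(Oc2ccc(NC(=O)Nc3cccc(C(F)(F)F)c3)cc2)ncn1` gives 4000 nM;
compound 3 `CCCNc1cc(Oc2ccc(NC(=O)Nc3cccc(C(F)(F)F)c3)cc2)ncn1` gives 32 nM.

Compound 3 has the lowest of these three numbers, but its separation from compound 1 lies within the scatter, so those two cannot be ranked against each other; only compound 2 stands clearly apart from both. Compound 4 `CC(C)CNc1cc(Oc2ccc(NC(=O)Nc3cccc(C(F)(F)F)c3)cc2)ncn1` has not yet been measured. It differs from compound 3 by methyl in place of hydrogen on a saturated chain carbon bound to two saturated chain carbons. The measured step that bears on this is a 1.3-fold lower number from compound 1 to compound 3 (0.10 log units; within the scatter), a lengthening of the same chain. The large steps of a 100-fold higher number from compound 1 to compound 2 (2.00 log units; beyond the scatter) and a 130-fold lower number from compound 2 to compound 3 (2.10 log units; beyond the scatter) exchange the amino group for a methoxy group and so do not speak to a chain change. A further methyl on the chain is therefore expected to give no step beyond the scatter in this assay. Compound 4 is expected at 30 nM, with a range from 10 nM to 90 nM. The expected step is a 1.1-fold lower number from compound 3 to compound 4 (0.03 log units; within the scatter).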

Compound 4, half-maximal inhibitory concentration: 50 nM
Compound 4: middle estimate off by 1.7-fold (0.22 log units), on the low side; the range from low to high includes it.
By their numbers in this assay, from the lowest: compounds 3, 1 and 4 (each within the scatter of the next); then compound 2.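

In this assay the added methyl turns the straight propylamino chain into a branched isobutylamino chain, yet the change stays within the scatter (a 1.6-fold higher number from compound 3 to compound 4 (0.19 log units; within the scatter)), as does the whole change from methylamino (a 1.3-fold higher number from compound 1 to compound 4 (0.10 log units; within the scatter)). A branch on this chain is therefore tolerated as well as a longer chain, while the large gap to the methoxy group remains (an 80-fold lower number from compound 2 to compound 4 (1.90 log units; beyond the scatter)). Nothing measured here accounts for this tolerance.

Still open, going by these compounds, is how large the group on this nitrogen can become, for instance a cyclohexyl ring or a longer chain ending in an amine. A dimethylamino group would also show whether the hydrogen on this nitrogen matters.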